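The source may hold more compounds than are shown below. What is called first, only, known or untested is meant among the compounds shown, and "the series" means these compounds.

Compounds measured so far in an assay on FRT-Jurkat cells for inhibition of nuclear factor NF-kappa-B complex (Homo sapiens), read by flow cytometry, with a stated time of 24 h, tested at 10 uM; on this read-out lower numbers stand for less inhibition and higher numbers for more inhibition at the one concentration tested (going by the name of the read-out):
compound 1, `COc1ccc(Nc2ccc3c(c2)C(=O)N(C2CCC(=O)NC2=O)C3=O)cc1`, giving 29%;
compound 2, `O=C1CCC(N2C(=O)c3cccc(Nc4ccccc4)c3C2=O)C(=O)N1`, giving 4%;
compound 3, `Cc1ccc(Nc2cccc3c2C(=O)N(C2CCC(=O)NC2=O)C3=O)cc1`, giving 9%.

Among these three, compound 1 stands highest in this assay. Its nearest neighbour is compound 3, which lies lower by a gap beyond the scatter, and compound 2 lies lower still, also beyond the scatter. Among the measured compounds shown here, the one step that joins two measured compounds differing in a single place is a number 5 percentage points higher from compound 2 to compound 3 (within the scatter), a methyl in place of hydrogen on an aromatic carbon, and it stays within the scatter.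

The unmeasured compound 4, `CC(=O)c1ccc(Nc2ccc3c(c2)C(=O)N(C2CCC(=O)NC2=O)C3=O)cc1`, is reached from compound 1 by acetyl in place of methoxy on an aromatic carbon. The group leaves and enters on an aromatic carbon of a six-membered aromatic ring of carbon only, para to a large group. For the measured compounds named here, no measured step exchanges one substituent for another on that ring; the only comparable small change on an aromatic carbon is a number 5 percentage points higher from compound 2 to compound 3 (within the scatter), which stayed within the scatter. On that basis, compound 4 is expected to show no step beyond the scatter in this assay, so the estimated step is a number 4 percentage points lower from compound 1 to compound 4 (within the scatter). The estimate for compound 4 in this assay is 25%, with a range from 5% to 45%.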

Compound 4, a percentage reported as inhibition, at one concentration (the size of the read-out at that concentration, not a potency): -2%
The estimate for compound 4 lay 27 percentage points above the measured number; the whole stated range lies above it.
By their numbers in this assay, from the lowest: compounds 4, 2 and 3 (each within the scatter of the next, the first and the last beyond it); then compound 1.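

In this assay, among the compounds shown here, this position proved far from indifferent to the group it carries: acetyl in place of methoxy on an aromatic carbon, para to a large group, gives a number 31 percentage points lower from compound 1 to compound 4 (beyond the scatter) and is the first single change in this set to reach beyond the scatter. For the compounds shown here, the only earlier step, a number 5 percentage points higher from compound 2 to compound 3 (within the scatter), replaced a hydrogen with a methyl and did not exchange one substituent for another, and it gave no sign that a change of this small size, from 2 to 3 heavy atoms, could matter this much. No measurement shown here bears on why the step is so large.

The compounds shown leave open whether the loss is particular to acetyl or would also follow from other groups at this place, such as an amine, a carboxylic acid or a nitrile, and where a plain hydrogen there would fall. They also leave open whether the same exchange of methoxy for acetyl would give a step of this size on the core of compound 3.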